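Shrinking the thiourea substituent of compound 1 to tert-butyl

The source may report more compounds than this note shows. Statements on the series, on what has been measured and on what is new or still open speak of the compounds shown alone.

Compound 1 `CC(C)(C)c1ccc(C(C)(C)/N=C(\S)NCc2ccc(NS(C)(=O)=O)c(F)c2)cc1`: > 30000 nM
Compound 2 `CCCc1ccc(C/N=C(\S)NCc2ccc(NS(C)(=O)=O)c(F)c2)cc1`: 460 nM
Compound 3 `CC(C)c1ccc(C/N=C(\S)NCc2ccc(NS(C)(=O)=O)c(F)c2)cc1`: 520 nM

In an assay for inhibition of transient receptor potential cation channel subfamily V member 1 (Rattus norvegicus), with a stated time of 10 min (on this read-out lower numbers stand for stronger inhibition and higher numbers for weaker inhibition), compound 1 gives only a limit, > 30000 nM, as noted in the limit of > 30000 nM in this assay, at which 1 of the 3 values shown sits. Within the data shown here, compound 2 gives 460 nM and compound 3 gives 520 nM; the only measured step, a 1.1-fold higher number from compound 2 to compound 3 (0.05 log units; within the scatter), concerns the substituent on the aromatic ring of the benzyl side and does not touch the carbon that is changed here. Compound 4 `CC(C)(C)/N=C(\S)NCc1ccc(NS(C)(=O)=O)c(F)c1` arises from compound 1 through (methyl in place of 4-(tert-butyl)phenyl on a saturated chain carbon bound to a double-bonded nitrogen and two saturated chain carbons). Among the measured compounds shown here, no measured step bears on this change, so the direction can only be guessed: compound 1 sits at the limit, and the benzyl-type compounds 2 and 3 sit at measurable numbers, but none of them shares the tert-butyl thiourea of compound 4. The number for compound 4 is estimated to lie near the weaker end of the scale, with a fair chance that it again returns only a limit. The expected step is an at least 2.5-fold lower number from compound 1 to compound 4 (0.39 log units; beyond the scatter). Compound 4 is estimated at 12000 nM, between 2500 nM and 40000 nM.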

Compound 4, half-maximal inhibitory concentration: > 30000 nM
Compound 4: only a limit was reported; the forecaster's own chance of this, stated with the estimate: 45%; at least 2.5-fold (0.39 log units) between middle value and limit.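

In this assay, compound 1 and compound 4 both return only a limit and not a number, so the step between them cannot be read: the limit of > 30000 nM in this assay, at which 2 of the 4 values shown sit.

The compounds shown leave open whether methyl in place of 4-(tert-butyl)phenyl changes the inhibition at all.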